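This account rests on a few compounds, and the source may have more. Where it says the series, first, only, none or still open, it means among the compounds named here.

In a functional assay on B16-F10 cells (Mus musculus) for inhibition, read by colorimetric assay and MTT assay, with a stated time of 72 h (on this read-out lower numbers stand for stronger inhibition and higher numbers for weaker inhibition), the starting picture is thin. Compound 1 `Cn1c2cnc1OCCCCCCCCCCCOc1ccccc1-2` offers no number, since its entry reads "not determined" (no result reported) and nothing more. Compound 2 `COc1ccccc1-c1cnc(OCCCc2ccccc2)n1C` gives 7000 nM in this measurement. Compound 3 `C=CCCCCOc1ncc(I)n1C` gives 51000 nM in the same measurement, which is the higher of the two numbers and so the weaker inhibition, with a gap beyond the usual scatter.

Compound 4 `C=CCCCCOc1nccn1C` has not been measured yet and differs from compound 3 in one place (hydrogen in place of iodo on an aromatic carbon), with hydrogen in place of iodo on an aromatic carbon. Among the measured compounds shown here, no measured pair isolates this swap, so the data give no direct guide to its size. Since compound 3 already stands at 51000 nM and the change is confined to one place, only a small move is expected in this assay, toward a somewhat higher number if it clears the scatter at all. The expected change is the estimated step of a 1.5-fold higher number from compound 3 to compound 4 (0.17 log units; within the scatter) and nothing larger is foreseen. For compound 4 the estimated value is 75000 nM with an expected range from 28000 nM to 200000 nM in this read-out.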

Compound 4, half-maximal inhibitory concentration: 51000 nM
For compound 4 the middle estimate is 1.5-fold (0.17 log units) above the measured one, and the stated range covers the measured number.
By their numbers in this assay, from the lowest: compound 2; then compounds 3 and 4 (each within the scatter of the next).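

Among the compounds shown here, replacing iodo with hydrogen on this aromatic carbon gives no change at the digits printed from compound 3 to compound 4 (within the scatter) in this assay, the first reading of a change at a single place, since the earlier compounds differ from one another in more than one place. Compound 3 and compound 4 read alike here, so the iodo group, with its one heavy atom, is not needed at this position for the weak inhibition seen in this pair. No measurement available here accounts for this result.

Iodo and hydrogen are the only two groups compared at this position, so whether an amine or a carboxylic acid on the same carbon would read alike remains open. For the compounds shown here, also open is whether a longer chain in place of the one shared by compound 3 and compound 4 would move the number.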